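A few compounds are considered here, and "the series" means these few. Any claim that something is new, unique, unknown or untested is made for them only; others in the source may bear on it.

Measured in a functional assay on HCT-116 cells (Homo sapiens) for inhibition, read by MTT assay, with a stated time of 48 h; a higher number here means a weaker inhibitor, a lower number a stronger inhibitor:
- Compound 1 `C/C=C/C(=O)N(Cc1ccc(OC)c([N+](=O)[O-])c1)c1cc(OC)c(OC)c(OC)c1`: 670 nM
- Compound 2 `COc1cc(NCc2ccccc2)cc(OC)c1OC`: > 80000 nM, a limit of the assay and not a number
- Compound 3 `COc1ccc(CN(C(C)=O)c2cc(OC)c(OC)c(OC)c2)cc1O`: 270 nM

Compound 3 has the lower of the two actual numbers in this assay, and the gap to compound 1 lies beyond the scatter. Compound 4 `C/C=C/C=C/C(=O)N(Cc1ccc(OC)c(O)c1)c1cc(OC)c(OC)c(OC)c1` differs from compound 3 by one change: penta-1,3-dien-1-yl in place of methyl on a carbonyl carbon. Here penta-1,3-dien-1-yl stands in place of methyl on a carbonyl carbon. Among the compounds with values here, no measured pair covers this change, so the expectation is loose. A modest move towards a higher number in this assay is expected, and no change beyond the scatter remains possible. The expected step is a 1.5-fold higher number from compound 3 to compound 4 (0.17 log units; within the scatter). The upper part of the range is set by compound 1 at 670 nM. For compound 4 the estimated value is 400 nM, with an expected range of 90 nM to 2000 nM.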

Compound 4, half-maximal inhibitory concentration: 180 nM
Estimate against measurement, compound 4: 2.2-fold (0.35 log units) above; measured number inside the range.
By their numbers in this assay, from the lowest: compounds 4 and 3 (each within the scatter of the next); then compound 1. At a limit, above all of these: compound 2.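

In this assay, penta-1,3-dien-1-yl in place of methyl on a carbonyl carbon gives a 1.5-fold lower number from compound 3 to compound 4 (0.18 log units; within the scatter). This position therefore accepts a chain of 5 carbons with 2 double bonds in place of methyl, with the pair remaining within the scatter. Nothing shown here bears on a cause for this step. Going by these compounds, it remains open how an amine or a carboxylic acid in place of penta-1,3-dien-1-yl on this carbonyl carbon would read in this assay. On these data alone, a longer saturated chain at the same place is equally open.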